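Amide aryl variation on the shared core: pyridin-3-yl

The source may report more compounds than this note shows. Statements on the series, on what has been measured and on what is new or still open speak of the compounds shown alone.

For the measured compounds named here, compound 2 `COc1cc2c(cc1OC)C(CC(=O)Nc1cccc(C)c1)CC2` gives the higher of the two numbers known so far: in a functional assay on the whole organism (strain Wistar) for inhibition, with Rattus norvegicus as the target, read by paw edema, with a stated time of 1 h, at a dose of 100 mg/kg (on this read-out higher numbers stand for more inhibition at the one dose given (going by the name of the read-out) and lower numbers for less inhibition), compound 2 gives 37.5%, while compound 1 `COc1cc2c(cc1OC)C(CC(=O)Nc1ccccc1C)CC2` in this assay gives 21.9%, the step of a number 15.6 percentage points higher from compound 1 to compound 2 (beyond the scatter). Compound 3 `COc1cc2c(cc1OC)C(CC(=O)Nc1cccnc1)CC2` differs from compound 2 by pyridin-3-yl in place of 3-methylphenyl on an amide-type nitrogen. Going by the values given here, no measured step moves a methyl off the ring or brings a ring nitrogen in, so the step from compound 1 to compound 2 bears only loosely on it. For compound 3 the expected step is a number 4.5 percentage points lower from compound 2 to compound 3 (within the scatter), not beyond the scatter, with a wide margin either way. Compound 3 is therefore estimated at 33%, from 15% to 50%.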

Compound 3, a percentage reported as inhibition, in the whole organism at one dose (the size of the read-out at that dose, not a potency): 25%
Estimate against measurement, compound 3: 8 percentage points above, within the range that was stated.
By their numbers in this assay, from the lowest: compounds 1 and 3 (each within the scatter of the next); then compound 2.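

In this assay, for the compounds shown here, the first change of the aryl ring itself on the amide-type nitrogen, pyridin-3-yl in place of 3-methylphenyl, gives a number 12.5 percentage points lower from compound 2 to compound 3 (beyond the scatter). Set against 2-methylphenyl, the same pyridin-3-yl group gives a number 3.1 percentage points higher from compound 1 to compound 3 (within the scatter), so this position admits a ring with a hetero atom, but here without keeping the number of compound 2. No measured data bear on the reason for this step. Open, going by these compounds, is whether an amine or a longer chain in place of the methyl of 3-methylphenyl would hold or raise that number.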